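Notes on cytotoxicity across the side-chain variants

This account rests on a few compounds, and the source may have more. Where it says the series, first, only, none or still open, it means among the compounds named here.

Compound 1 `CS(=O)(=O)c1nn(Cc2nc3cc(Cl)ccc3n2CCCCO)c2cnccc12`, compound 2 `COCCOCCn1c(Cn2nc(S(C)(=O)=O)c3ccncc32)nc2cc(Cl)ccc21` and compound 3 `CS(=O)(=O)c1nn(Cc2nc3cc(Cl)ccc3n2CCC(O)C(F)(F)F)c2cnccc12` share one core and differ only in the chain carried on the aromatic nitrogen. In an ADME assay on HEp-2 cells (Homo sapiens) for cytotoxicity, with a stated time of 4 days (on this read-out higher numbers stand for lower toxicity in this test and lower numbers for higher toxicity in this test), compound 1 reaches only the limit > 100000 nM. In this assay compound 2 likewise reaches only the limit > 100000 nM. Compound 3 also gives only the limit > 100000 nM in this assay. Hence the steps a step that the two limits leave unreadable from compound 1 to compound 2, a step that the two limits leave unreadable from compound 1 to compound 3 and a step that the two limits leave unreadable from compound 2 to compound 3 cannot be sized; the limit of > 100000 nM in this assay, at which 3 of the 3 values shown sit, holds for every value so far, and compound 3 stands together with the others at that limit, with no order among them.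

Compound 4 `CS(=O)(=O)c1nn(Cc2nc3cc(Cl)ccc3n2CCC(O)C(F)F)c2cnccc12` differs from compound 3 by hydrogen in place of fluoro on a saturated chain carbon bound to two fluorine atoms and a saturated chain carbon. Among the measured compounds shown here, no measured step bears on this change directly, and the measured steps themselves are all unreadable, so no direction can be taken from them; the change is smaller than those separating compounds 1, 2 and 3, which all remained at the limit. Compound 4 is therefore expected to remain at the limit as well, with an expected step of a number no higher from compound 3 to compound 4 (the limit leaves the size open). The expected value for compound 4 in this assay is 100000 nM, between 50000 nM and 200000 nM.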

Compound 4, half-maximal cytotoxic concentration: > 100000 nM
Compound 4: no number, only a limit; the forecaster's own chance of this, stated with the estimate: 85%; the middle value lies on the limit itself.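

Among the compounds shown here, compound 4 also gives only a limit in this assay, so no step linking it to compound 1, compound 2 or compound 3 can be read: the limit of > 100000 nM in this assay, at which 4 of the 4 values shown sit.

The compounds shown leave open whether these side chains differ in cytotoxicity, and at what concentration any of them becomes toxic to the cells.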